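Carbamoyl on the ring nitrogen: compound 3 to compound 4

The source may report more compounds than this note shows. Statements on the series, on what has been measured and on what is new or still open speak of the compounds shown alone.

In a functional assay on U-937 cells (Homo sapiens) for cytotoxicity, read by MTT assay, with a stated time of 3 days (on this read-out higher numbers stand for weaker inhibition and lower numbers for stronger inhibition), compound 1 (`N#Cc1c(Nc2ccccc2)nc(SCc2nc3ccccc3[nH]2)nc1-c1ccccc1`) gives 3.28 nM, compound 2 (`CNc1nc(SCc2nc3ccccc3[nH]2)nc(-c2ccccc2)c1C#N`) gives 19.2 nM and compound 3 (`N#Cc1c(NNC(N)=S)nc(SCc2nc3ccccc3[nH]2)nc1-c1ccccc1`) gives 3 nM. Compound 3 thus sits level with compound 1 at the low end of the three numbers, as a 1.1-fold lower number from compound 1 to compound 3 (0.04 log units; within the scatter) stays within the scatter. Compound 2 stands apart, with a 6.4-fold lower number from compound 2 to compound 3 (0.81 log units; beyond the scatter) beyond the scatter.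

Compound 4 (`N#Cc1c(NC(N)=O)nc(SCc2nc3ccccc3[nH]2)nc1-c1ccccc1`) carries one change, (a group of 3 heavy atoms (1 carbon, 1 nitrogen, 1 oxygen; no ring) in place of a group of 4 heavy atoms (1 carbon, 2 nitrogen, 1 sulfur; no ring), on a nitrogen on an aromatic ring), on a nitrogen on an aromatic ring. Among the measured compounds shown here, no measured compound carries the carbamoyl group, so only the other steps at this nitrogen bear on it. Exchanging the substituent there left the number unmoved in one case, a 1.1-fold lower number from compound 1 to compound 3 (0.04 log units; within the scatter), while the methyl of compound 2 gave a modest shift, a 5.9-fold higher number from compound 1 to compound 2 (0.77 log units; beyond the scatter). A small rise is therefore the likeliest outcome, with a shift as large as that of compound 2 still possible. The expected step is a 1.7-fold higher number from compound 3 to compound 4 (0.22 log units; within the scatter), probably within the scatter. For compound 4 the estimate is 5 nM, with an expected range of 1.5 nM to 18 nM.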

Compound 4, half-maximal inhibitory concentration: 3.37 nM
The estimate for compound 4 lay 1.5-fold (0.17 log units) above the measured number, and the stated range covers the measured number.
By their numbers in this assay, from the lowest: compounds 3, 1 and 4 (each within the scatter of the next); then compound 2.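

At this nitrogen on an aromatic ring, carbamoyl holds the number in this assay level with the group it replaces, with a 1.1-fold higher number from compound 3 to compound 4 (0.05 log units; within the scatter) and also a 1.0-fold higher number from compound 1 to compound 4 (0.01 log units; within the scatter) both within the scatter. Phenyl, carbamoyl and the group of compound 3 thus give matching numbers, while compound 2 goes against any wider tolerance, its methyl remaining apart with a 5.7-fold lower number from compound 2 to compound 4 (0.76 log units; beyond the scatter) beyond the scatter. Nothing in hand explains this level of tolerance or the separate place of methyl.

On these data alone, it remains open whether methyl is a lone exception or whether ethyl or a longer alkyl chain on this nitrogen would give a similar rise. Also open, as far as these compounds go, is whether a substituent ending in a carboxylic acid or an amine would keep the number level with compound 4.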